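A few compounds are considered here, and "the series" means these few. Any claim that something is new, unique, unknown or untested is made for them only; others in the source may bear on it.

Measured compounds:
compound 1 `Cc1noc(C)c1-c1cnc(N)c(Oc2ccc(C(=O)Nc3ccccc3)cc2)n1` — 26600 nM
compound 2 `Cc1noc(C)c1-c1cnc(N)c(Oc2ccc(C(=O)Nc3cccc(Cl)c3)cc2)n1` — 11500 nM

In a functional assay on U-87MG ATCC cells for inhibition, with U-87 MG (Homo sapiens) as the target, read by MTT assay, with a stated time of 72 h (on this read-out higher numbers stand for weaker inhibition and lower numbers for stronger inhibition), compound 2 gives the lower of the two numbers; compound 1 sits higher by a 2.3-fold lower number from compound 1 to compound 2 (0.36 log units; beyond the scatter). Compound 3 `Cc1noc(C)c1-c1cnc(N)c(Oc2ccc(C(=O)Nc3cccc(Cl)n3)cc2)n1` differs from compound 2 by 6-chloropyridin-2-yl in place of 3-chlorophenyl on an amide-type nitrogen. Within the data shown here, no measured step covers a change of this kind: the single step seen, from compound 1 to compound 2, concerns only the chloro atom, which compound 3 keeps. With nothing to anchor the ring swap, a step of a 1.0-fold higher number from compound 2 to compound 3 (0.02 log units; within the scatter) is expected, that is none beyond the scatter, and compound 3 is estimated at 12000 nM, within 5000 nM to 30000 nM.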

Compound 3, half-maximal inhibitory concentration: 64100 nM
Beside the measured number, compound 3's estimate is 5.3-fold (0.73 log units) below it; the whole stated range lies below it.
By their numbers in this assay, from the lowest: compound 2; then compound 1; then compound 3.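

In this assay, exchanging 3-chlorophenyl for 6-chloropyridin-2-yl on the amide-type nitrogen gives a 5.6-fold higher number from compound 2 to compound 3 (0.75 log units; beyond the scatter), so this position responds to the ring itself and not only to the chloro atom. The gain seen with chloro does not carry over to the new ring, since replacing the plain phenyl gives a 2.4-fold higher number from compound 1 to compound 3 (0.38 log units; beyond the scatter), a weaker result despite the chloro atom. No supporting data explain this loss.

As far as these compounds go, it remains open whether the ring nitrogen alone sets this trend. A plain pyridin-2-yl group, or a methoxy or amino group in place of chloro, would help separate these contributions.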